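A few compounds are considered here, and "the series" means these few. Any claim that something is new, unique, unknown or untested is made for them only; others in the source may bear on it.

In a functional assay on U-251 cells (Homo sapiens) for inhibition, read by MTT assay, with a stated time of 48 h (a higher number here means a weaker inhibitor, a lower number a stronger inhibitor), compound 1 `C#CCN(C)CCCOc1cc(NC(=O)CCCCCCCCC(=O)NO)ccc1Cl` gives 16200 nM and compound 2 `C#CCN(C)CCCOc1cc(NC(=O)CCCCCCCC(=O)NO)ccc1Cl` gives 4780 nM, with a 3.4-fold lower number from compound 1 to compound 2 (0.53 log units; beyond the scatter). Compound 3 `C#CCN(C)CCCOc1cc(NC(=O)CCCCCCC(=O)NO)c(Cl)cc1Cl` gives 8670 nM, which lies within the usual scatter of both other values, so it takes no clear place in order among them. Compound 4 `C#CCN(C)CCCOc1cc(NC(=O)CCCCCCC(=O)NO)ccc1Cl` has not yet been measured. It departs from compound 3 at one point: hydrogen in place of chloro on an aromatic carbon. For the measured compounds named here, no measured step makes this exchange. Going by the values given here, the only measured step is a modest one on the saturated chain, so it bears on the question only indirectly. The nearest guide is compound 2, which also lacks this chloro group and stands at 4780 nM. Only a small move toward a lower number is therefore expected, not one beyond the scatter. The expected change is a 1.6-fold lower number from compound 3 to compound 4 (0.20 log units; within the scatter). For compound 4 the estimated value is 5500 nM, with an expected range of 2000 nM to 15000 nM.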

Compound 4, half-maximal inhibitory concentration: 600 nM
Compound 4: middle estimate off by 9.2-fold (0.96 log units), on the high side, outside the stated range (below it).
By their numbers in this assay, from the lowest: compound 4; then compounds 2, 3 and 1 (each within the scatter of the next, the first and the last beyond it).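

In this assay, for the compounds shown here, the chloro group para to the 3-(methyl(propargyl)amino)propoxy group proves far from neutral, with a 14-fold lower number from compound 3 to compound 4 (1.16 log units; beyond the scatter) on this chain, a change that no earlier step had tested. Going by these compounds alone, the chain also counts for more than the single earlier step suggested, since the shorter chain stands apart once this chloro group is absent, with an 8.0-fold lower number from compound 2 to compound 4 (0.90 log units; beyond the scatter) and a 27-fold lower number from compound 1 to compound 4 (1.43 log units; beyond the scatter). Nothing measured here accounts for the size of either effect.

The compounds shown leave open whether another group on this aromatic carbon, such as fluoro, methoxy or an amine, would keep a number as low as that of compound 4. They also leave open whether this chloro group would have a similar effect on a longer chain, and whether a still shorter chain would lower the number further.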